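This account rests on a few compounds, and the source may have more. Where it says the series, first, only, none or still open, it means among the compounds named here.

Measured compounds:
compound 1 `COc1cc2c(cc1OC)C(CC(=O)Nc1cccc(Cl)c1)CC2` — 25.8%
compound 2 `COc1cc2c(cc1OC)C(CC(=O)Nc1ccc(C)cc1)CC2` — 32.8%
compound 3 `COc1cc2c(cc1OC)C(CC(=O)Nc1cccnc1)CC2` — 34.4%

In a functional assay on the whole organism (strain Wistar) for inhibition, with Rattus norvegicus as the target, read by paw edema, with a stated time of 4 h, at a dose of 100 mg/kg (on this read-out higher numbers stand for more inhibition at the one dose given (going by the name of the read-out) and lower numbers for less inhibition), compound 3 holds the highest of the three numbers, yet the steps leading to it, a number 8.6 percentage points higher from compound 1 to compound 3 (within the scatter) and a number 1.6 percentage points higher from compound 2 to compound 3 (within the scatter), both stay within the scatter, so the three compounds are not truly told apart. Compound 4 `COc1cc2c(cc1OC)C(CC(=O)Nc1ccncc1)CC2` has not been measured; it differs from compound 3 by pyridin-4-yl in place of pyridin-3-yl on an amide-type nitrogen. Every measured step changes the group on the amide-type nitrogen, and all of them, including a number 7 percentage points higher from compound 1 to compound 2 (within the scatter), stayed within the scatter; none swaps one pyridinyl for another. The change is therefore expected to bring no step beyond the scatter, a number 1.4 percentage points lower from compound 3 to compound 4 (within the scatter). Compound 4 is estimated at 33%, with a range from 20% to 46%.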

Compound 4, a percentage reported as inhibition, in the whole organism at one dose (the size of the read-out at that dose, not a potency): 45.3%
Estimate against measurement, compound 4: 12.3 percentage points below, and the stated range covers the measured number.
By their numbers in this assay, from the lowest: compounds 1, 2 and 3 (each within the scatter of the next); then compound 4.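

Among these compounds, putting pyridin-4-yl in place of pyridin-3-yl on the amide-type nitrogen gives the first step here to pass the scatter (a number 10.9 percentage points higher from compound 3 to compound 4 (beyond the scatter)). The two groups have the same atoms and the same counts, so at this position how the atoms are joined can matter, not only which atoms are present. Compound 4 also stands clear of both phenyl amides (a number 12.5 percentage points higher from compound 2 to compound 4 (beyond the scatter); a number 19.5 percentage points higher from compound 1 to compound 4 (beyond the scatter)).

Nothing measured here accounts for the gap between the two pyridinyl groups. On these data alone, whether pyridin-2-yl or pyrimidin-4-yl on this nitrogen would match compound 4 also stays open.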